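From 4-bromophenyl to 2-chlorophenyl on a shared core

The source may hold more compounds than are shown below. What is called first, only, known or untested is meant among the compounds shown, and "the series" means these compounds.

Measured so far in a functional assay on Raji cells (Homo sapiens) for cytotoxicity, read by CCK-8 assay, with a stated time of 24 h; a higher number here means a weaker inhibitor, a lower number a stronger inhibitor:
- Compound 1 `C=CC(=O)N1C(=O)CC(c2ccc(C(F)(F)F)cc2)Sc2ccccc21`: 47600 nM
- Compound 2 `C=CC(=O)N1C(=O)CC(c2ccc(Br)cc2)Sc2ccccc21`: 51300 nM

Among the measured compounds shown here, compound 2 stands level with compound 1, the only other compound measured, since their two values lie within the usual scatter of repeated measurements. Neither can be called the stronger. The next compound, compound 3 `C=CC(=O)N1C(=O)CC(c2ccccc2Cl)Sc2ccccc21`, keeps the shared core, and 2-chlorophenyl takes the place of 4-bromophenyl on a saturated ring carbon: 2-chlorophenyl in place of 4-bromophenyl on a saturated ring carbon.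

For the measured compounds named here, only one measured step bears on this change: a 1.1-fold higher number from compound 1 to compound 2 (0.03 log units; within the scatter). There, bromo replaced trifluoromethyl on an aromatic carbon, and the number stayed within the scatter. Going by the values given here, that step is only a partial guide, as no measured compound carries a 2-substituted phenyl group. Starting from compound 2 at 51300 nM, no step beyond the scatter is expected in this assay, in either direction. The estimated change is a 1.0-fold lower number from compound 2 to compound 3 (0.01 log units; within the scatter). For compound 3 the expected value is 50000 nM, with an estimated range from 24000 nM to 100000 nM.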

Compound 3, half-maximal inhibitory concentration: 50400 nM
For compound 3 the middle estimate is 1.0-fold (0.00 log units) below the measured one; the measured number falls inside the stated range.
By their numbers in this assay, from the lowest: compounds 1, 3 and 2 (each within the scatter of the next).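

Measured by this assay, the exchange of 4-bromophenyl for 2-chlorophenyl gives a 1.0-fold lower number from compound 2 to compound 3 (0.01 log units; within the scatter) and so leaves compound 3 level with compound 2, even though the halogen and the substitution pattern on the phenyl ring both differ. Compound 1 and compound 2 had differed only in which group their phenyl ring carried, whereas compound 3 is the first of these compounds with a 2-substituted phenyl group, which extends the evidence on this saturated ring carbon beyond a single substitution pattern and shows that this combined change, too, stays within the scatter. Nothing available here accounts for this flat result.

On these data alone, all three compounds still carry a halogen-bearing or fluorine-bearing phenyl group on this carbon, so it remains open whether a phenyl ring bearing an amine or a carboxylic acid, or a longer alkyl chain in place of the phenyl ring, would give a step beyond the scatter. The vinylcarbonyl group on the ring nitrogen is also the same throughout, so its part in these numbers cannot be judged from these compounds.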